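This account rests on a few compounds, and the source may have more. Where it says the series, first, only, none or still open, it means among the compounds named here.

Working notes on the series in an ADME assay on TERT-RPE1 cells (Homo sapiens) for cytotoxicity, read by MTT assay, with a stated time of 72 h; a higher number here means a weaker inhibitor, a lower number a stronger inhibitor. Compound 1 `C=C1CN/C(=N/c2ccccc2)S1` reads > 100000 nM, which is a limit of the assay and not a number. Two compounds give numeric readings. Compound 2 `COc1ccc(/C=C2/CN(C)/C(=N/c3ccc(C)cc3)S2)cc1` stands at 65700 nM, the higher of the two numbers, and compound 3 `COc1ccc(/C=C2\S/C(=N\c3ccc(C)c(Cl)c3)N(C)C2=O)cc1` stands at 23000 nM, a gap beyond the scatter. Compound 2 is therefore a weak inhibitor by the numbers in hand, and it is the reference point for the next compound.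

Compound 4 `COc1ccc(/C=C2/CN(C)/C(=N/c3ccc(Br)cc3)S2)cc1` has not yet been measured. It differs from compound 2 by one substitution: bromo in place of methyl on an aromatic carbon. This is bromo in place of methyl on an aromatic carbon, para to a large group, with the rest of the structure unchanged.

Going by the values given here, no measured pair shows this change, so the expectation rests on compound 2 at 65700 nM alone. In this assay, no step beyond the scatter is expected, with a slight lean toward a lower number. The estimated step is a 1.3-fold lower number from compound 2 to compound 4 (0.12 log units; within the scatter). A reading at the limit of the assay also remains possible. For compound 4 the expected value is 50000 nM, with an estimated range of 22000 nM to 100000 nM.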

Compound 4, half-maximal inhibitory concentration: 61300 nM
Compound 4: the middle estimate sits 1.2-fold (0.09 log units) below what was measured; the measured number falls inside the stated range.
By their numbers in this assay, from the lowest: compound 3; then compounds 4 and 2 (each within the scatter of the next). At a limit, above all of these: compound 1.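

In this assay, going by these compounds alone, the change from 4-methylphenyl to 4-bromophenyl is the first single-place comparison, and it gives a 1.1-fold lower number from compound 2 to compound 4 (0.03 log units; within the scatter). At this position, on an aromatic carbon para to a large group, bromo in place of methyl therefore gives no separation between the two compounds, although this rests on one pair and on one swap of a single heavy atom. Compound 2 and compound 4 both give numbers, so this step is a direct reading and not a comparison against: the limit of > 100000 nM in this assay, at which 1 of the 4 values shown sits.

It remains open whether another group at this position, such as an amine, a carboxylic acid or a longer chain, would separate from compound 2 in this assay, since methyl and bromo are the only two groups shown there. Compound 3 differs from compound 2 and compound 4 in more than one place, so the compounds shown do not tell which of those differences goes with its reading.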